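Chlorophenyl for Methylphenyl on the Anilino Nitrogen

The compounds below may be only part of what the source reports. "The series", "measured", "known", "first", "only" and "open" are said of these compounds alone.

Measured so far in a functional assay on MGC-803 cells (Homo sapiens) for inhibition, read by MTT assay, with a stated time of 72 h; on this read-out lower numbers stand for stronger inhibition and higher numbers for weaker inhibition:
compound 1 `C#CCSc1nc(NCCC#N)c2ccncc2n1` gives > 80000 nM, which is a limit of the assay rather than a number.
compound 2 `C#CCSc1nc(Nc2ccc(C)cc2)c2ccncc2n1` gives 8090 nM.

Compound 2 therefore holds the only number shown; the remaining value is a limit (the limit of > 80000 nM in this assay, at which 1 of the 2 values shown sits). Within the data shown here, the single measured step, an at least 9.8-fold lower number from compound 1 to compound 2 (0.99 log units; beyond the scatter), concerns exchanging 2-cyanoethyl for 4-methylphenyl on the nitrogen, so it shows that an aromatic group there is tolerated, but it says nothing about one aromatic group against another.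

Compound 3 `C#CCSc1nc(Nc2ccccc2Cl)c2ccncc2n1` differs from compound 2 by 2-chlorophenyl in place of 4-methylphenyl on a nitrogen on an aromatic ring. Among the measured compounds shown here, no measured step bears directly on this aryl-to-aryl swap, so the expectation rests only on compound 2 and its value 8090 nM. The expected step of a 1.0-fold lower number from compound 2 to compound 3 (0.00 log units; within the scatter) is none beyond the scatter. Compound 3 is estimated at 8000 nM, within a range from 2500 nM to 30000 nM.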

Compound 3, half-maximal inhibitory concentration: 27600 nM
For compound 3 the middle estimate is 3.5-fold (0.54 log units) below the measured one, within the range that was stated.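

The aromatic groups on this nitrogen are not interchangeable. In this assay there is a 3.4-fold higher number from compound 2 to compound 3 (0.53 log units; beyond the scatter), even though 2-chlorophenyl and 4-methylphenyl have the same count of heavy atoms. The 2-chlorophenyl group still gives a lower number than 2-cyanoethyl, with an at least 2.8-fold lower number from compound 1 to compound 3 (0.46 log units; beyond the scatter), but compound 1 sits at a limit of the assay, not at a number, so this step gives only a minimum size: the limit of > 80000 nM in this assay, at which 1 of the 3 values shown sits.

Compound 2 and compound 3 differ both in the substituent, methyl against chlorine, and in where it sits on the phenyl ring, so these two compounds cannot show which of those differences matters. Going by these compounds, how plain phenyl, 4-chlorophenyl or 2-methylphenyl would behave on this nitrogen stays open, and those groups would pull the two differences apart.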